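Swapping one ring heteroatom on a sulfonylmethyl arm

The source may report more compounds than this note shows. Statements on the series, on what has been measured and on what is new or still open speak of the compounds shown alone.

Three compounds share a sulfonyl group carrying a saturated chain carbon that bears a small five-membered ring, and a fourth is still to be measured. Compound 3 `COc1ccc(C2=NN(c3ccccc3)C(c3ccc(C)cc3)C2S(=O)(=O)CC2=NCCS2)cc1` and compound 1 `COc1ccc(C2=NN(c3ccccc3)C(c3ccc(C)cc3)C2S(=O)(=O)CC2=NCCO2)cc1` have the same core; compound 2 `O=S(=O)(CC1=NCCS1)c1c(-c2ccc(Cl)cc2)noc1-c1ccc(Cl)cc1` is built on a different core, and the difference between the two cores is not broken down here. The new compound 4 `O=S(=O)(CC1=NCCO1)c1c(-c2ccc(Cl)cc2)noc1-c1ccc(Cl)cc1` keeps the core of compound 2.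

In a functional assay, tested at 75 ug/mL (a lower number here means a weaker effect, a higher number a stronger effect of the compound at the concentration tested), compound 3 gives 43.9%. In this assay compound 1 gives 64.3%. The change between them, (a group of 5 heavy atoms (3 carbon, 1 nitrogen, 1 oxygen; one five-membered non-aromatic ring with 2 hetero atoms) in place of a group of 5 heavy atoms (3 carbon, 1 nitrogen, 1 sulfur; one five-membered non-aromatic ring with 2 hetero atoms), on a saturated chain carbon bound to a sulfonyl sulfur), made a step of a number 20.4 percentage points higher from compound 3 to compound 1 (beyond the scatter). For compound 2 only the verdict "not active" (no number reported) is reported in this assay, with no number behind it.

Compound 4 arises from compound 2 by the same kind of change, (a group of 5 heavy atoms (3 carbon, 1 nitrogen, 1 oxygen; one five-membered non-aromatic ring with 2 hetero atoms) in place of a group of 5 heavy atoms (3 carbon, 1 nitrogen, 1 sulfur; one five-membered non-aromatic ring with 2 hetero atoms), on a saturated chain carbon bound to a sulfonyl sulfur), and the place is the same in words for both pairs. Among the compounds with values here, whether the gain seen from compound 3 to compound 1 carries over onto a different core cannot be checked with the compounds at hand; the only guide is that the starting point, compound 2, showed no measurable effect, so even a modest gain of the size seen in a number 20.4 percentage points higher from compound 3 to compound 1 (beyond the scatter) would leave the new compound low. Compound 4 is therefore expected to reach about 15% in this assay, within a broad range from 0% to 40%, with a real chance that it too is reported only as inactive.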

Compound 4, a percentage reported as activity, at one concentration (the size of the read-out at that concentration, not a potency): "not active" (no number reported)
Nothing numeric was reported for compound 4, and the estimate cannot be compared.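

In this assay compound 2 gives "not active" (no number reported) and compound 4 gives "not active" (no number reported), so with no number on either side, no step can be read between them. Nothing available offers an explanation for this outcome. The compounds shown leave open whether the change behind a number 20.4 percentage points higher from compound 3 to compound 1 (beyond the scatter) has any effect on the core of compound 2.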